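The source may hold more compounds than are shown below. What is called first, only, known or untested is meant among the compounds shown, and "the series" means these compounds.

Measured so far in a functional assay on HeLa cells (Homo sapiens) for cytotoxicity, read by ELISA, with a stated time of 2 days; on this read-out higher numbers stand for weaker inhibition and lower numbers for stronger inhibition:
Compound 1 `Oc1cccc(-c2cc(-c3ccccc3)cc(-c3ccsc3)n2)c1`: 13800 nM
Compound 2 `Oc1cccc(-c2cc(-c3ccccc3)nc(-c3cccs3)c2)c1`: 15300 nM

Among the compounds with values here, these are the only two numbers available, and they lie within the usual scatter of repeated measurements. Compound 2, at 15300 nM, therefore cannot be ranked against compound 1, at 13800 nM. The two structures differ in more than one place, so they offer no clean single-change comparison.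

The next compound is compound 3 `Oc1cccc(-c2cc(-c3ccccc3)nc(-c3cccnc3)c2)c1`. It carries pyridin-3-yl in place of thiophen-2-yl on an aromatic carbon, next to the ring nitrogen of the shared core, so a five-membered aromatic ring gives way to a six-membered one: pyridin-3-yl in place of thiophen-2-yl on an aromatic carbon.

Within the data shown here, no measured compound carries pyridin-3-yl, so the data give no direct guide to this swap. The only hint is that the two measured compounds sit close together, which gives no reason to expect a shift in either direction in this assay. The expected change is a 1.0-fold lower number from compound 2 to compound 3 (0.01 log units; within the scatter), which would stay within the scatter. The estimate for compound 3 is 15000 nM, with an expected range from 6000 nM to 40000 nM.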

Compound 3, half-maximal inhibitory concentration: 17500 nM
Compound 3: middle estimate off by 1.2-fold (0.07 log units), on the low side, and the stated range covers the measured number.
By their numbers in this assay, from the lowest: compounds 1, 2 and 3 (each within the scatter of the next).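

In this assay, pyridin-3-yl in place of thiophen-2-yl on an aromatic carbon next to the ring nitrogen gives a 1.1-fold higher number from compound 2 to compound 3 (0.06 log units; within the scatter). Within the data shown here, this is the first comparison here in which only one place changes, and it shows that, at this position, a six-membered aromatic ring can stand in for a five-membered one without a change that can be told apart from the scatter, even though sulfur gives way to nitrogen as the ring's hetero atom. No measurement here offers an explanation for this result.

The two rings compared are both aromatic and each holds one hetero atom, so the compounds shown leave open whether a quite different group at this position, such as an amine, a carboxylic acid or a longer carbon chain, would move the number in either direction. Also open, going by these compounds, is whether the number responds to a change elsewhere, for example a methoxy group in place of the hydroxyl of the 3-hydroxyphenyl group, which stays the same in compound 2 and compound 3.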